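The source may hold more compounds than are shown below. What is called first, only, known or untested is meant among the compounds shown, and "the series" means these compounds.

Of the compounds shown here, three have been measured in a physicochemical assay for lipophilicity, at pH 7.4; a lower number here means a more polar compound, a higher number a more lipophilic compound. Compound 1 `CC(C)CN(c1ccc(F)cc1)S(=O)(=O)c1ccc2c(c1)C(O)CC(C1CCOCC1)O2` gives 3.39, the lowest of the three numbers. Compound 2 `CCc1ccc(N(CC2CCC2)S(=O)(=O)c2ccc3c(c2)C(O)CC(C2CCOCC2)O3)cc1` gives 4.01, and compound 3 `CCc1ccc(N(CC(C)C)S(=O)(=O)c2ccc(OCC3CCOCC3)c3c2CCC3O)cc1` gives 4.55; both of these lie beyond the scatter above the number for compound 1. These pairs differ in more than one place, so the values alone are what they show.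

Compound 4 `CC(C)CN(c1ccc(F)cc1F)S(=O)(=O)c1ccc2c(c1)C(O)CC(C1CCOCC1)O2` is the next compound, and it differs from compound 1 in a single place: fluoro in place of hydrogen on an aromatic carbon. For a change of this kind, in this assay, the expected step is small and upward, or no more than the scatter. The value for compound 4 is estimated at 3.55, between 3.25 and 3.85, so the expected step is a number 0.16 log units higher from compound 1 to compound 4 (within the scatter).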

Compound 4, distribution coefficient: 3.53
Compound 4: middle estimate off by 0.02 log units, on the high side; measured number inside the range.
By their numbers in this assay, from the lowest: compounds 1 and 4 (each within the scatter of the next); then compound 2; then compound 3.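

In this assay, among these compounds, going from 4-fluorophenyl to 2,4-difluorophenyl gives a number 0.14 log units higher from compound 1 to compound 4 (within the scatter), the first comparison here in which only one place differs. A second fluoro on this aromatic carbon, ortho to a large group, therefore leaves a difference that cannot be told from repeat measurement, and compound 1 and compound 4 cannot be ranked. No measured evidence bears on why this is so. Still open, from the compounds shown here alone, is whether a methoxy group or an amine at this same carbon would give a step beyond the scatter.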